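This account rests on a few compounds, and the source may have more. Where it says the series, first, only, none or still open, it means among the compounds named here.

Working notes on the series.

Compound 2 `Cc1cc(C)n(CCOC2CC(=O)Nc3c2c(C)nn3-c2ncnc3nc[nH]c23)n1` gives 16 nM in a functional assay on HEK293 cells for agonist activity at G-protein coupled receptor 39 (Homo sapiens), read by scintillation proximity assay and inositol phosphate accumulation, with a stated time of 75 min, in the presence of a further agent that is not named here (a lower number here means that less compound is needed, a higher number that more compound is needed for the effect), and stands highest of the three numbers measured. Compound 1 `Cc1nn(-c2ncnc3nc[nH]c23)c2c1C(OCC(=O)c1ccc(F)cc1)CC(=O)N2` gives 3 nM in this assay, and compound 3 `Cc1nn(-c2ncnc3nc[nH]c23)c2c1C(C(=O)NCc1ccccc1)CC(=O)N2` gives 5 nM. The step of a 5.3-fold higher number from compound 1 to compound 2 (0.73 log units; beyond the scatter) was modest and beyond the scatter; the step of a 3.2-fold lower number from compound 2 to compound 3 (0.51 log units; beyond the scatter) was likewise modest and beyond the scatter.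

Compound 4 `Cc1nn(-c2ncnc3nc[nH]c23)c2c1C(OCc1ccc(C(C)C)cc1)CC(=O)N2` differs from compound 2 in one place: 4-isopropylphenyl in place of (3,5-dimethyl-1H-pyrazol-1-yl)methyl on a saturated chain carbon bound to an oxygen on a saturated carbon. Both measured steps bear on this change. Each exchanges the five-membered aromatic ring with two hetero atoms for a group that carries a six-membered aromatic ring of carbon only, or the reverse, and in both the compound with the carbon-only ring gives the lower number. The change to compound 4 runs in the same direction as the step from compound 2 to compound 3, so a lower number is expected, of a size comparable to those two steps.

Compound 4 is therefore expected to give 5 nM in this assay, within a range of 2 nM to 15 nM, which corresponds to an expected step of a 3.2-fold lower number from compound 2 to compound 4 (0.51 log units; beyond the scatter).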

Compound 4, half-maximal effective concentration: 5 nM
For compound 4 middle estimate and measured number coincide at the digits printed; the measured number falls inside the stated range.
By their numbers in this assay, from the lowest: compounds 1, 3 and 4 (each within the scatter of the next); then compound 2.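

The step of a 3.2-fold lower number from compound 2 to compound 4 (0.51 log units; beyond the scatter) shows that this place tolerates an ether-linked 4-isopropylbenzyl: a carbon-only group with no hydrogen-bond acceptors replaces 2-(3,5-dimethyl-1H-pyrazol-1-yl)ethyl and gives the lower number. The step of a 1.7-fold higher number from compound 1 to compound 4 (0.22 log units; within the scatter) lies within the scatter, so the carbonyl of compound 1 is not needed to hold a number of this order, and 4-isopropylphenyl and (4-fluorophenyl)carbonyl cannot be told apart here. Nothing available explains either step.

The compounds shown do not separate the part played by the isopropyl group from that of the carbon-only ring, which an unsubstituted benzyl would address. Also open, going by these compounds, is how this place responds to an amine or a carboxylic acid on the ring, or to a longer chain before it.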